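Furan to thiophene on the saturated ring carbon of compound 3

The compounds below may be only part of what the source reports. "The series", "measured", "known", "first", "only" and "open" are said of these compounds alone.

Of the compounds shown here, three sharing one core have been measured in an assay on membranes from CHO cells for displacement of a labelled ligand from adenosine receptor A1 (Homo sapiens), read by scintillation counting, with a stated time of 60 min, tested at 1 uM; a lower number here means less inhibition, a higher number more inhibition at the concentration tested (going by the name of the read-out). Compound 1 `CCCOC(=O)C1=C(C)NC(=O)NC1c1cccs1` gives 43%, the highest of the three numbers. Compound 2 `CC1=C(C(=O)C2CC2)C(c2cccs2)NC(=O)N1` gives 1%; the one measured step that connects two of these compounds, a number 42 percentage points lower from compound 1 to compound 2 (beyond the scatter), replaces propoxy with cyclopropyl on a carbonyl carbon. Compound 3 `CCC(CC)OC(=O)C1=C(C)NC(=O)NC1c1ccoc1` gives 17%, the second highest of the three numbers; compound 2 lies nearer to it and compound 1 further from it, and both gaps fall beyond the scatter.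

Compound 4 `CCC(CC)OC(=O)C1=C(C)NC(=O)NC1c1cccs1` is not yet measured. It differs from compound 3 in one place: thiophen-2-yl in place of furan-3-yl on a saturated ring carbon. For the measured compounds named here, no measured step bears directly on this change; the only step recorded, from compound 1 to compound 2, alters the group on the carbonyl carbon and leaves the five-membered aromatic ring untouched. Compound 1, which also carries thiophen-2-yl on that saturated ring carbon, gives 43%, but its ester chain differs from that of compound 3 and compound 4, so it offers only a loose hint. Compound 4 is therefore expected to show a number 13 percentage points higher from compound 3 to compound 4 (beyond the scatter), a modest rise. The estimate for compound 4 in this assay is 30%, with a range from 10% to 55%.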

Compound 4, a percentage reported as inhibition, at one concentration (the size of the read-out at that concentration, not a potency): 13%
Compound 4: middle estimate off by 17 percentage points, on the high side, and the stated range covers the measured number.
By their numbers in this assay, from the lowest: compound 2; then compounds 4 and 3 (each within the scatter of the next); then compound 1.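

In this assay, the ring on the saturated ring carbon has so far been compared only with (pentan-3-yl)oxy on the carbonyl carbon, and there the change gives a number 4 percentage points lower from compound 3 to compound 4 (within the scatter) and leaves furan-3-yl and thiophen-2-yl unseparated by this read-out. With thiophen-2-yl held in place, the group around the carbonyl carbon does separate the compounds: adding ethyl on the saturated chain carbon bound to an oxygen, read in the listed direction, gives a number 30 percentage points lower from compound 1 to compound 4 (beyond the scatter) and shows that propoxy and (pentan-3-yl)oxy differ, while (pentan-3-yl)oxy in place of cyclopropyl gives a number 12 percentage points higher from compound 2 to compound 4 (beyond the scatter) and is a smaller step. Nothing at hand explains any of these steps.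

For the compounds shown here, whether furan-3-yl and thiophen-2-yl would also read alike with propoxy on the carbonyl carbon remains open, since the single comparison of the two rings rests on one ester chain. As far as these compounds go, what a phenyl ring on the saturated ring carbon, or a butoxy chain on the carbonyl carbon, would give in this assay also remains open.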